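Cytotoxicity in the series: a pyridinylethyl replacement

The compounds below may be only part of what the source reports. "The series", "measured", "known", "first", "only" and "open" are said of these compounds alone.

Of the compounds shown here, three have been tested in an ADME assay on MT2 cells (Homo sapiens) for cytotoxicity, read by XTT assay, with a stated time of 4 days; a lower number here means that less compound is tolerated, a higher number that more compound is tolerated. Compound 1 `CC(=O)N1CCc2nc(C)c(C(OC(C)(C)C)C(=O)O)c(-c3ccc(C)cc3)c2C1` gives > 40000 nM, which is a limit of the assay and not a number. Compound 3 `COC(=O)N1CCc2nc(C)c(C(OC(C)(C)C)C(=O)O)c(-c3ccc(C)cc3)c2C1` gives > 40000 nM, also a limit. The step between them is thus not readable: a step that the two limits leave unreadable from compound 1 to compound 3. Compound 2 `Cc1nc2c(c(-c3cc(F)c4c(c3C)CCCO4)c1[C@H](OC(C)(C)C)C(=O)O)CN(CC1CC1c1ccccc1)CC2` gives > 40000 nM, again a limit. All measured values in this assay sit at the same place, namely (the limit of > 40000 nM in this assay, at which 3 of the 3 values shown sit).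

Compound 4 `Cc1nc2c(c(-c3cc(F)c4c(c3C)CCCO4)c1[C@H](OC(C)(C)C)C(=O)O)CN(CCCc1ccncc1)CC2` has not been measured. It differs from compound 2 in one place: 2-(pyridin-4-yl)ethyl in place of 2-phenylcyclopropyl on a saturated chain carbon bound to an amine nitrogen in a ring. Among the measured compounds shown here, no measured step bears on this change; the only step in the set, from compound 1 to compound 3, is unreadable, and no measured pair carries either the 2-phenylcyclopropyl or the 2-(pyridin-4-yl)ethyl group. For the measured compounds named here, because every value so far sits at the limit of > 40000 nM in this assay, at which 3 of the 3 values shown sit, compound 4 is expected to sit there too, and a step that the limit leaves unreadable from compound 2 to compound 4 is expected to show no step beyond the scatter. Compound 4 is estimated at 50000 nM, between 30000 nM and 100000 nM.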

Compound 4, half-maximal cytotoxic concentration: > 40000 nM
Compound 4 ended at the assay's limit (the forecaster's own chance of this, stated with the estimate: 85%); the middle value lies beyond the limit too.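

No step can be read from compound 2 to compound 4 in this assay, and every value shown is a limit of the assay, not a number: the limit of > 40000 nM in this assay, at which 4 of the 4 values shown sit.

The compounds shown leave open how much compound each tolerates beyond that limit, and whether any change to the shared core or its groups would give a readable value.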